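Hydroxy-methoxyphenyl in Place of Fluorophenyl on a Shared Core

A few compounds are considered here, and "the series" means these few. Any claim that something is new, unique, unknown or untested is made for them only; others in the source may bear on it.

Compound 1 `OC[C@H]1O[C@@H](n2cnc3c(NCc4cccc(F)c4)ncnc32)[C@H](O)[C@@H]1O`: > 166000 nM
Compound 2 `COc1cccc(CNc2ncnc3c2ncn3[C@@H]2O[C@H](CO)[C@@H](O)[C@H]2O)c1`: "not determined" (no result reported)
Compound 3 `OC[C@H]1O[C@@H](n2cnc3c(NCc4ccc(F)cc4Cl)ncnc32)[C@H](O)[C@@H]1O`: > 166000 nM

Three compounds on a shared core have been examined in a functional assay on G-361 cells (Homo sapiens) for antiproliferative activity, with a stated time of 72 h; on this read-out lower numbers stand for stronger inhibition and higher numbers for weaker inhibition. Compound 1 gives only a limit of the assay, > 166000 nM. Compound 3 likewise gives only a limit, > 166000 nM. For compound 2 the read-out is "not determined" (no result reported). For the measured compounds named here, the single step with two measured ends is a step that the two limits leave unreadable from compound 1 to compound 3, which swaps 2-chloro-4-fluorophenyl for 3-fluorophenyl on a saturated chain carbon bound to a nitrogen on an aromatic ring; since both ends sit at the limit of > 166000 nM in this assay, at which 2 of the 3 values shown sit, its size cannot be read. Compound 1 therefore stands at the limit, with nothing beneath it to rank against.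

Compound 4 `COc1cccc(CNc2ncnc3c2ncn3[C@@H]2O[C@H](CO)[C@@H](O)[C@H]2O)c1O` differs from compound 1 by 2-hydroxy-3-methoxyphenyl in place of 3-fluorophenyl on a saturated chain carbon bound to a nitrogen on an aromatic ring. Going by the values given here, no measured step bears on this change, and the one comparable step is unreadable. Compound 4 is expected to remain near the limit, a step of an at least 1.1-fold lower number from compound 1 to compound 4 (0.04 log units; that floor lies within the scatter) in this assay. The estimate for compound 4 is 150000 nM, between 30000 nM and 600000 nM, most likely again reported as a limit.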

Compound 4, half-maximal inhibitory concentration: 148000 nM
The estimate for compound 4 lay 1.0-fold (0.01 log units) above the measured number, and the stated range covers the measured number.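

Compound 4 is the only compound shown with this kind of group on a saturated chain carbon bound to a nitrogen on an aromatic ring that gives a number rather than a limit: in this assay compound 4 gives 148000 nM as a measured value. With 2-hydroxy-3-methoxyphenyl entering, the readable result is an at least 1.1-fold lower number from compound 1 to compound 4 (0.04 log units; that floor lies within the scatter) on replacing 3-fluorophenyl, and an at least 1.1-fold lower number from compound 3 to compound 4 (0.04 log units; that floor lies within the scatter) on replacing 2-chloro-4-fluorophenyl. Each step starts from a limit and gives only a floor, and the values shown still gather at that limit: the limit of > 166000 nM in this assay, at which 2 of the 4 values shown sit.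

Whether the hydroxy or the methoxy of compound 4 accounts for the measured number remains open. The compounds shown also leave open how an amine or a carboxylic acid on this ring would read.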